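The source may hold more compounds than are shown below. What is called first, only, known or untested is meant among the compounds shown, and "the series" means these compounds.

For the measured compounds named here, in a functional assay on MES-SA/Dx5 cells (Homo sapiens) for inhibition, with a stated time of 72 h, in the presence of a further agent that is not named here (a lower number here means a stronger inhibitor, a higher number a weaker inhibitor), compound 2 (`COCc1cc(CN2CCCC2)c(O)c2ncccc12`) gives 3550 nM as its single reading. Compound 1 (`Oc1c(CN2CCCC2)cc(Cl)c2cccnc12`) also carries pyrrolidin-1-yl, on a core of its own, and gives 3210 nM; 3160 nM (2 entries), a value within the usual scatter of that of compound 2. Compound 3 (`CC1CCN(Cc2cc(Cl)c3cccnc3c2O)CC1`) has the core of compound 1 with 4-methylpiperidin-1-yl, and in this assay compound 3 gives 1590 nM; 1580 nM (2 entries). Compound 4 (`COCc1cc(CN2CCC(C)CC2)c(O)c2ncccc12`) is compound 2 with one change (4-methylpiperidin-1-yl in place of pyrrolidin-1-yl on a saturated chain carbon bound to an aromatic carbon), 4-methylpiperidin-1-yl in place of pyrrolidin-1-yl on a saturated chain carbon bound to an aromatic carbon. Going by the values given here, no measured pair shows this change on the core of compound 2, so a modest move toward stronger inhibition is expected, about the size of the gap between compound 1 at 3210 nM; 3160 nM (2 entries) and compound 3 at 1590 nM; 1580 nM (2 entries) on the other core. The expected step is a 2.0-fold lower number from compound 2 to compound 4 (0.29 log units; within the scatter) on this reasoning. For compound 4 the estimated value is 1800 nM with 900 nM to 3500 nM as the expected range.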

Compound 4, half-maximal inhibitory concentration: 4680 nM
Beside the measured number, compound 4's estimate is 2.6-fold (0.41 log units) below it; the measured number lies above the stated range.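

In this assay, placing 4-methylpiperidin-1-yl instead of pyrrolidin-1-yl on the saturated chain carbon gives a 1.3-fold higher number from compound 2 to compound 4 (0.12 log units; within the scatter). For the compounds shown here, this is the first direct reading of the change on this core, and the two rings cannot be told apart here, although the entering group is the larger one. Compound 2 and compound 4 each rest on a single reading.

This change alters ring size and adds a methyl together, so plain piperidin-1-yl would be needed to separate the two. Going by these compounds, whether morpholin-4-yl or an open-chain diethylamino group would move the number beyond the scatter stays open.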